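Series notes: exchange at an aromatic carbon of compound 3

A few compounds are considered here, and "the series" means these few. Any claim that something is new, unique, unknown or untested is made for them only; others in the source may bear on it.

Measured so far:
Compound 1 `CSc1nc2ccccn2c(=N)c1S(=O)(=O)c1ccc(OC(F)(F)F)cc1` gives 420 nM in an assay on HeLa cells for displacement of a labelled ligand from 5-hydroxytryptamine receptor 6 (Homo sapiens); on this read-out higher numbers stand for weaker inhibition and lower numbers for stronger inhibition.
Compound 2 `CSc1nc2ccccn2/c(=N\C(C)=O)c1S(=O)(=O)c1ccccc1` gives 83 nM in this assay.
Compound 3 `C[S+]([O-])c1nc2ccccn2c(=N)c1S(=O)(=O)c1ccccc1` gives 250 nM in this assay.

Compound 3 stands second highest of the three numbers; its value and that of compound 1 lie within the scatter, while compound 2 sits beyond the scatter at a lower number.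

Compound 4 `N=c1c(S(=O)(=O)c2ccccc2)c(NCCO)nc2ccccn12` differs from compound 3 by a group of 4 heavy atoms (2 carbon, 1 nitrogen, 1 oxygen; no ring) in place of a group of 3 heavy atoms (1 carbon, 1 oxygen, 1 sulfur; no ring), on an aromatic carbon. No step of this kind is seen among the measured compounds, so the expected size rests on nothing shown; a step of modest size, in either direction, or none beyond the scatter, is expected in this assay. For compound 4 the estimate is 200 nM, within 60 nM to 700 nM, which is expected to mean a 1.3-fold lower number from compound 3 to compound 4 (0.10 log units; within the scatter).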

Compound 4, half-maximal inhibitory concentration: 42 nM
For compound 4 the middle estimate is 4.8-fold (0.68 log units) above the measured one, and the stated range ends above it.
By their numbers in this assay, from the lowest: compounds 4 and 2 (each within the scatter of the next); then compounds 3 and 1 (each within the scatter of the next).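

In this assay, (2-hydroxyethyl)amino on the aromatic carbon next to the ring nitrogen, replacing the group carried there by compound 3, gives a 6.0-fold lower number from compound 3 to compound 4 (0.77 log units; beyond the scatter). Among these compounds, this is the first change read at this position, and it shows that the position can move the number beyond the scatter. No measurement here accounts for the step.

On these data alone, whether the hydroxyl or the amino nitrogen carries the step remains open; a plain ethylamino group would separate the two. A longer chain such as 3-hydroxypropylamino would show whether chain length matters at this position.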